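Difluorophenyl replaces acetamidophenyl on a triazole nitrogen

The compounds below may be only part of what the source reports. "The series", "measured", "known", "first", "only" and "open" are said of these compounds alone.

Measured so far in an ADME assay on HUVEC cells (Homo sapiens) for antiproliferative activity, read by MTT assay, with a stated time of 48 h; on this read-out higher numbers stand for weaker inhibition and lower numbers for stronger inhibition:
- compound 1, `COc1ccc(-n2nncc2CN2C(=O)C3(C(C#N)=C(N)Oc4c3c3nc5ccccc5nc3c3ccccc43)c3ccccc32)cc1`, a limit of > 50000 nM
- compound 2, `N#CC1=C(N)Oc2c(c3nc4ccccc4nc3c3ccccc23)C12C(=O)N(Cc1cnnn1-c1ccc(N)cc1)c1ccccc12`, a limit of > 50000 nM
- compound 3, `CC(=O)Nc1ccc(-n2nncc2CN2C(=O)C3(C(C#N)=C(N)Oc4c(N)cc5nc6ccccc6nc5c43)c3ccccc32)cc1`, a limit of > 50000 nM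

All three values are limits of this assay rather than numbers, and compound 3 sits at that limit like the others. Among the compounds with values here, the only pair differing in one place, from compound 1 to compound 2 with amino in place of methoxy on an aromatic carbon, gives a step that the two limits leave unreadable from compound 1 to compound 2, so no step size can be read from the measured compounds. What the numbers share is the limit of > 50000 nM in this assay, at which 3 of the 3 values shown sit.

Compound 4, `N#CC1=C(N)Oc2c(N)cc3nc4ccccc4nc3c2C12C(=O)N(Cc1cnnn1-c1c(F)cccc1F)c1ccccc12`, differs from compound 3 in one place: 2,6-difluorophenyl in place of 4-acetamidophenyl on an aromatic nitrogen.

Within the data shown here, no measured step bears directly on this exchange on the triazole nitrogen. Among the measured compounds shown here, the single measured step is unreadable, and every value stands at the limit, so there is no evidence that any change in this part of the molecule moves the read-out. The expectation is therefore that compound 4 also shows no antiproliferative effect within the range of this assay, and the expected step of a number no higher from compound 3 to compound 4 (the limit leaves the size open) is none beyond the scatter. Compound 4 is estimated at 50000 nM in this assay, within a range from 20000 nM to 50000 nM, most likely again reported only as a limit.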

Compound 4, half-maximal inhibitory concentration: > 50000 nM
Compound 4 gave a limit, no number; the forecaster's own chance of this, stated with the estimate: 80%; the middle value lies on the limit itself.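

No step can be read from compound 3 to compound 4, since both values are limits of this assay and not numbers. All the compounds shown share one result: the limit of > 50000 nM in this assay, at which 4 of the 4 values shown sit.

The compounds shown leave open which change to these structures, if any, would bring a measurable value in this read-out.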